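Notes on the step from compound 1 to compound 3

The source may report more compounds than this note shows. Statements on the series, on what has been measured and on what is new or still open speak of the compounds shown alone.

Measured so far:
compound 1 `CC(C)CCN(CCC(C)C)c1ccc(C(=O)N2CCc3ccc(OS(N)(=O)=O)cc3C2)cc1`, 90.8%
compound 2 `CCN(Cc1ccccc1)Cc1ccc(S(=O)(=O)N2CCc3ccc(OS(N)(=O)=O)cc3C2)cc1`, 31%

In an assay on HEK293 cells for inhibition of Steryl-sulfatase (Homo sapiens), tested at 1 uM (a lower number here means a weaker effect, a higher number a stronger effect of the compound at the concentration tested), compound 1 gives 90.8%, the higher of the two numbers. Compound 2 gives 31%, which lies below compound 1 beyond the scatter. Among the measured compounds shown here, no step between measured compounds differing in one place is available, so the series offers no calibrated single change.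

Compound 3 `CN(CCN1CCCCC1)c1ccc(C(=O)N2CCc3ccc(OS(N)(=O)=O)cc3C2)cc1` differs from compound 1 in one place: methyl(2-(piperidin-1-yl)ethyl)amino in place of diisopentylamino on an aromatic carbon. In this assay a moderate downward step, beyond the scatter, is expected: a number 20.8 percentage points lower from compound 1 to compound 3 (beyond the scatter). Compound 3 is estimated at 70%, within 40% to 92%.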

Compound 3, a percentage reported as inhibition, at one concentration (the size of the read-out at that concentration, not a potency): 26.8%
The estimate for compound 3 lay 43.2 percentage points above the measured number; measured number outside the range, below it.
By their numbers in this assay, from the lowest: compounds 3 and 2 (each within the scatter of the next); then compound 1.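

In this assay, among the compounds shown here, methyl(2-(piperidin-1-yl)ethyl)amino in place of diisopentylamino gives a number 64 percentage points lower from compound 1 to compound 3 (beyond the scatter), the first single change that can be read. This place on the aromatic carbon, para to a large group, therefore does not accept every amino substituent of similar heavy-atom count, as the entering group brings a six-membered non-aromatic ring and a second nitrogen. Nothing measured here accounts for the step.

Which feature of the change carries the step stays open. A dipentylamino or a piperidin-1-yl group on the same carbon would help separate the ring, the second nitrogen and the chains.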